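This account rests on a few compounds, and the source may have more. Where it says the series, first, only, none or still open, it means among the compounds named here.

In a functional assay for agonist activity at G protein-coupled receptor 88 (Homo sapiens), read by HTRF and cAMP accumulation (a higher number here means that more compound is needed for the effect, a lower number that less compound is needed), compound 1 `N[C@H](CN(C(=O)[C@@H]1C[C@H]1c1ccccc1)c1ccc(-c2ccccc2)cc1)C1CCCCC1` gives 0.66 nM. Compound 2 `CC[C@H](C)[C@H](N)CN(C(=O)[C@@H]1C[C@H]1c1ccccc1F)c1ccc(-c2ccccc2)cc1` differs from it in more than one place, and in this assay compound 2 gives 650 nM, the higher of the two numbers seen so far; the gap between compound 1 and compound 2 lies well beyond the scatter of repeated measurements. Because the two measured compounds differ in several places at once, the numbers do not show which of the differences carries that gap.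

Compound 3 `CC[C@H](C)[C@H](N)CN(C(=O)[C@@H]1C[C@H]1c1ccncc1)c1ccc(-c2ccccc2)cc1` is made from compound 2 by a single change: pyridin-4-yl in place of 2-fluorophenyl on a saturated ring carbon. Going by the values given here, no measured pair shows this change on its own, so there is no direct guide to its effect. Among the compounds with values here, the expectation is that the step of a 1.4-fold higher number from compound 2 to compound 3 (0.14 log units; within the scatter) stays within the scatter or is at most a modest one, with no firm lean in either direction, since the only measured comparison mixes several changes. For compound 3 in this assay the estimate is 900 nM, expected to fall somewhere between 200 nM and 5000 nM.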

Compound 3, half-maximal effective concentration: 1500 nM
Estimate against measurement, compound 3: 1.7-fold (0.22 log units) below; measured number inside the range.
By their numbers in this assay, from the lowest: compound 1; then compound 2; then compound 3.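

In this assay, going by these compounds alone, replacing 2-fluorophenyl with pyridin-4-yl on a saturated ring carbon of the three-membered ring gives a 2.3-fold higher number from compound 2 to compound 3 (0.36 log units; beyond the scatter), the first change at this position that can be read on its own. The step is modest, but it shows that this position responds to the type of aromatic ring it carries: here, a ring of carbon only with a fluorine is exchanged for a ring with a hetero atom and a hydrogen-bond acceptor, and more compound is needed for the effect. No measurement shown gives a cause for this step.

Within the data shown here, the single step swaps the fluorine-bearing carbon ring for the nitrogen-containing ring as a whole, so it cannot show whether losing the fluorine or gaining the ring nitrogen matters more. A pyridin-3-yl or 4-fluorophenyl group at this place could help separate those two parts, and the size of the step may also differ on the core of compound 1.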